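One Side Chain Exchanged in a Paw Edema Series

The compounds below may be only part of what the source reports. "The series", "measured", "known", "first", "only" and "open" are said of these compounds alone.

Three compounds have been measured in a functional assay on the whole organism (strain albino) for inhibition, with Rattus norvegicus as the target, read by paw edema, with stated times of 1 h and 3 h, at a dose of 20 mmol/kg by the intraperitoneal route; a higher number here means a stronger effect of the compound at the dose given, a lower number a weaker effect:
compound 1 `N#Cc1c2n(c(=O)n(-c3ccccc3)c1=N)CCCCC2N1CCCC1` gives 93.4%
compound 2 `N#CC1=C(/N=C/Nc2ccccc2)N(c2ccccc2)C(=O)N2CCCCC(N3CCCC3)C12` gives 79.3%
compound 3 `N#CC1=C(NCC(=O)O)N(c2ccccc2)C(=O)N2CCCCC(N3CCCC3)C12` gives 89.2%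

Compound 2 stands lowest of the three numbers; compound 3 is its nearest neighbour, and compound 1 lies furthest, beyond the scatter above it. Compound 4 `N#CC1=C(NCC(=O)N2CCCCC2)N(c2ccccc2)C(=O)N2CCCCC(N3CCCC3)C12` differs from compound 2 as follows: a group of 10 heavy atoms (7 carbon, 2 nitrogen, 1 oxygen; one six-membered non-aromatic ring with 1 hetero atom) in place of a group of 9 heavy atoms (7 carbon, 2 nitrogen; one six-membered aromatic ring of carbon only), on a double-bonded ring carbon. For the measured compounds named here, only one measured step bears on this change, the exchange of the same leaving group on the same double-bonded ring carbon, which gave a number 9.9 percentage points higher from compound 2 to compound 3 (within the scatter). That step stayed within the scatter, and nothing measured points to a larger move for a different chain entering at that carbon. Compound 4 is therefore expected to give about 85%, within a range of 71% to 96%. The estimated step of a number 5.7 percentage points higher from compound 2 to compound 4 (within the scatter) is expected to remain within the scatter.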

Compound 4, a percentage reported as inhibition, in the whole organism at one dose (the size of the read-out at that dose, not a potency): 53.5%
Compound 4: middle estimate off by 31.5 percentage points, on the high side; measured number outside the range, below it.
By their numbers in this assay, from the lowest: compound 4; then compounds 2, 3 and 1 (each within the scatter of the next, the first and the last beyond it).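

At the double-bonded ring carbon, a change of chain can clearly shift the response in this assay, giving a number 25.8 percentage points lower from compound 2 to compound 4 (beyond the scatter), whereas the earlier exchange there stayed within the scatter. The end of the chain also matters: piperidin-1-yl in place of hydroxy on a carbonyl carbon gives a number 35.7 percentage points lower from compound 3 to compound 4 (beyond the scatter). Nothing in the data shown explains this drop. Going by these compounds, it remains open whether a methyl ester or a smaller amine such as dimethylamine on that carbonyl carbon would read like compound 3 or like compound 4, and what a longer chain at the double-bonded ring carbon would do.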